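The compounds below may be only part of what the source reports. "The series", "measured", "known", "first", "only" and "open" are said of these compounds alone.

Compound 1 `CC1=CC[C@H](C(C)(C)NC(=S)N/N=C/c2ccccc2O)CC1`, compound 2 `CC1=CC[C@H](C(C)(C)NC(=S)N/N=C/c2ccc(N(C)C)cc2)CC1` and compound 3 `CC1=CC[C@H](C(C)(C)NC(=S)N/N=C/c2ccc(F)cc2)CC1` share one core and differ only in the aryl group on the carbon with a double bond to nitrogen. In a functional assay on MCF7 cells (Homo sapiens) for inhibition, read by sulforhodamine B assay, with a stated time of 48 h (a higher number here means a weaker inhibitor of growth, a lower number a stronger inhibitor of growth), compound 1 gives 2200 nM and compound 2 gives 26800 nM. Compound 3 reaches only a limit of the assay, > 100000 nM (the limit of > 100000 nM in this assay, at which 1 of the 3 values shown sits). The measured steps into it were an at least 45-fold higher number from compound 1 to compound 3 (1.65 log units; beyond the scatter) and an at least 3.7-fold higher number from compound 2 to compound 3 (0.57 log units; beyond the scatter). Compound 4 `CC1=CC[C@H](C(C)(C)NC(=S)N/N=C/c2ccc(Cl)cc2)CC1` differs from compound 3 by chloro in place of fluoro on an aromatic carbon. Going by the values given here, no measured step swaps one halogen for another; the two steps ending at compound 3 were large or at least modest, both toward weaker inhibition. Compound 4 is therefore expected to remain weak, with an at least 1.2-fold lower number from compound 3 to compound 4 (0.09 log units; that floor lies within the scatter), and its estimated value is 80000 nM, between 20000 nM and 300000 nM.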

Compound 4, concentration for 50% growth inhibition: 18300 nM
Compound 4: middle estimate off by 4.4-fold (0.64 log units), on the high side; measured number outside the range, below it.
By their numbers in this assay, from the lowest: compound 1; then compounds 4 and 2 (each within the scatter of the next). At a limit, above all of these: compound 3.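

In this assay, the halogen on this aromatic carbon, para to a large group, makes a clear difference: chloro in place of fluoro gives an at least 5.4-fold lower number from compound 3 to compound 4 (0.73 log units; beyond the scatter). Compound 3 stands only at a limit: the limit of > 100000 nM in this assay, at which 1 of the 4 values shown sits.

With chloro in this place, the step is a 1.5-fold lower number from compound 2 to compound 4 (0.17 log units; within the scatter), so chloro and dimethylamino cannot be told apart, while the step from the 2-hydroxyphenyl compound remains an 8.3-fold higher number from compound 1 to compound 4 (0.92 log units; beyond the scatter). The compounds shown leave open whether bromo or methoxy in this place would match chloro. They also leave open how a 2-hydroxyphenyl group carrying a chloro would compare.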